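A few compounds are considered here, and "the series" means these few. Any claim that something is new, unique, unknown or untested is made for them only; others in the source may bear on it.

In a functional assay on MCF7 cells (Homo sapiens) for cytotoxicity, read by sulforhodamine B assay, with a stated time of 48 h (a lower number here means a stronger inhibitor, a higher number a weaker inhibitor), the three measured compounds are:

Compound 1 `COc1ccc(C2C(C#N)=C(/N=C/c3ccccc3)Oc3nc(Nc4ccc(S(N)(=O)=O)cc4)sc32)cc1` gives 33600 nM.
Compound 2 `COc1ccc(C2C(C#N)=C(/N=C/c3ccccc3Cl)Oc3nc(Nc4ccc(S(N)(=O)=O)cc4)sc32)cc1` gives 10300 nM.
Compound 3 `COc1ccc(C2C(C#N)=C(/N=C/c3ccc(F)cc3)Oc3nc(Nc4ccc(S(N)(=O)=O)cc4)sc32)cc1` gives 28900 nM.

Compound 1 has the highest number of the three, so it is the weakest inhibitor shown. Compound 3 sits nearest to it, and the step of a 1.2-fold lower number from compound 1 to compound 3 (0.07 log units; within the scatter), so the two cannot be told apart. Compound 2 lies furthest away, with a 3.3-fold lower number from compound 1 to compound 2 (0.51 log units; beyond the scatter), a real but modest gain.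

Compound 4 `COc1ccc(C2C(C#N)=C(/N=C/c3ccc(N(C)C)cc3)Oc3nc(Nc4ccc(S(N)(=O)=O)cc4)sc32)cc1` differs from compound 1 in one place: dimethylamino in place of hydrogen on an aromatic carbon.

Among the measured compounds shown here, two measured steps bear on this. The closest comparison is compound 3, where a fluoro at the same place on the same ring left the number unchanged within the scatter (a 1.2-fold lower number from compound 1 to compound 3 (0.07 log units; within the scatter)). The chloro of compound 2 sits elsewhere on that ring, and its step was a 3.3-fold lower number from compound 1 to compound 2 (0.51 log units; beyond the scatter). For the measured compounds named here, no compound carries a dimethylamino anywhere, so the expected size of this step rests on these two examples only. Taken together they suggest a small change at most, more likely toward a lower number than a higher one, and possibly none beyond the scatter.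

On that basis compound 4 is expected to give 22000 nM in this assay, within a range of 9000 nM to 50000 nM, which would be a step of a 1.5-fold lower number from compound 1 to compound 4 (0.18 log units; within the scatter).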

Compound 4, half-maximal inhibitory concentration: 36200 nM
Beside the measured number, compound 4's estimate is 1.6-fold (0.22 log units) below it; low and high end bracket the measured number.
By their numbers in this assay, from the lowest: compound 2; then compounds 3, 1 and 4 (each within the scatter of the next).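

In this assay, the aromatic carbon para to a large group accepts a dimethylamino of 3 heavy atoms with no visible effect: a 1.1-fold higher number from compound 1 to compound 4 (0.03 log units; within the scatter), and a 1.3-fold higher number from compound 3 to compound 4 (0.10 log units; within the scatter). Hydrogen, fluoro and dimethylamino at this place therefore cannot be told apart, even though these groups differ considerably in size, so the three compounds form one group with no order among them. Only compound 2 stands apart from the new compound, with a 3.5-fold higher number from compound 2 to compound 4 (0.55 log units; beyond the scatter), but that step swaps 4-(dimethylamino)phenyl for 2-chlorophenyl and so changes both the group and where it sits; nothing available here explains why this place shows so little response.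

On these data alone, it remains open whether a chloro at the place para to a large group would match the number of compound 2, which would show whether the group itself or its place matters more. As far as these compounds go, it is also open whether a carboxylic acid, a primary amine or a longer alkyl chain at this same carbon would move the number beyond the scatter.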